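This account rests on a few compounds, and the source may have more. Where it says the series, first, only, none or still open, it means among the compounds named here.

Going by the values given here, in a functional assay on MCF7 cells (Homo sapiens) for antiproliferative activity, read by fluorescence, with a stated time of 3 days (a higher number here means a weaker inhibitor, a lower number a stronger inhibitor), compound 1 `CCCCCSc1nc(OC(=O)c2cc3ccccc3o2)c2cn[nH]c2n1` gives 18900 nM, and it stands level with its only measured neighbour, compound 2 `O=C(Oc1nc(SCCc2ccccc2)nc2[nH]ncc12)c1cc2ccccc2o1`, which gives 18900 nM. Compound 3 `CCCCCSc1nc(OC(=O)c2ccco2)c2cn[nH]c2n1` keeps the shared core and the sulfur chain of compound 1 and alters only the group on the carbonyl carbon, where furan-2-yl stands in place of 1-benzofuran-2-yl: furan-2-yl in place of 1-benzofuran-2-yl on a carbonyl carbon. Among the compounds with values here, the only measured step is no change at the digits printed from compound 1 to compound 2 (within the scatter), with phenyl in place of propyl on the sulfur chain. That step lies away from the carbonyl carbon, so it bears only loosely on this change. Both measured compounds carry 1-benzofuran-2-yl, so the data show no direction for the swap, and no step beyond the scatter is expected. The estimated step is a 1.1-fold higher number from compound 1 to compound 3 (0.02 log units; within the scatter). For compound 3 the estimated value is 20000 nM, with an expected range from 8000 nM to 50000 nM.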

Compound 3, half-maximal inhibitory concentration: 18900 nM
Compound 3: the middle estimate sits 1.1-fold (0.02 log units) above what was measured; low and high end bracket the measured number.
By their numbers in this assay, from the lowest: compounds 1, 2 and 3 (each within the scatter of the next).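

Removing the six-membered aromatic ring of carbon only, so that 1-benzofuran-2-yl becomes furan-2-yl on the carbonyl carbon, gives no change at the digits printed from compound 1 to compound 3 (within the scatter) in this assay. Going by these compounds alone, compound 1 and compound 2 both carry 1-benzofuran-2-yl, so this is the first reading of a change at this position. In this pair, the five-membered aromatic ring alone is enough to hold the measured level, and no measurement shown explains why.

Going by these compounds, it remains open whether any group on this carbonyl carbon can move the number beyond the scatter, since only these two ring groups appear there. A plain phenyl ring, a pyridine ring, a methyl group or an open carbon chain could test whether an aromatic ring is needed at all.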